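The compounds below may be only part of what the source reports. "The series", "measured", "known", "first", "only" and "open" are said of these compounds alone.

Going by the values given here, in a functional assay on HeLa cells (Homo sapiens) for antiproliferative activity, read by CCK-8 assay, with a stated time of 72 h (a higher number here means a weaker inhibitor, a lower number a stronger inhibitor), compound 2 `COc1cc(-c2ncncc2-c2ccc(OCC(F)(F)F)cc2)cc(OC)c1OC` gives 10200 nM, the higher of the two numbers so far, against 220 nM for compound 1 `COc1cc(-c2ncncc2-c2ccc(SC)cc2)cc(OC)c1OC`. Compound 3 `COc1cc(-c2ncncc2-c2ccc(OC(C)C)cc2)cc(OC)c1OC` differs from compound 2 in one place: isopropyl in place of 2,2,2-trifluoroethyl on an oxygen on an aromatic ring. Among the compounds with values here, the only measured step at this place is a 46-fold higher number from compound 1 to compound 2 (1.67 log units; beyond the scatter), which is large and beyond the scatter, and it introduced 2,2,2-trifluoroethoxy in place of methylsulfanyl. Isopropoxy is untested, so a moderate move toward a lower number is expected, smaller than that step. The expected change is a 5.1-fold lower number from compound 2 to compound 3 (0.71 log units; beyond the scatter). For compound 3 the estimated value is 2000 nM, with an expected range of 400 nM to 9000 nM.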

Compound 3, half-maximal inhibitory concentration: 8360 nM
Estimate against measurement, compound 3: 4.2-fold (0.62 log units) below; the range from low to high includes it.
By their numbers in this assay, from the lowest: compound 1; then compounds 3 and 2 (each within the scatter of the next).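

In this assay, the change from 2,2,2-trifluoroethyl to isopropyl on the oxygen gives a 1.2-fold lower number from compound 2 to compound 3 (0.09 log units; within the scatter), so on this oxygen the fluorinated and the unfluorinated chain cannot be told apart. The large loss seen with compound 2 therefore also appears without fluorine, with a 38-fold higher number from compound 1 to compound 3 (1.58 log units; beyond the scatter). No measurement on hand explains why either oxygen-linked group stands so far from methylsulfanyl. The compounds shown leave open whether the sulfur atom or the size of the group matters more. Methoxy and ethylsulfanyl at this place would help to separate the two.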